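From 3-fluorophenyl to phenyl: compound 3 awaits measurement

A few compounds are considered here, and "the series" means these few. Any claim that something is new, unique, unknown or untested is made for them only; others in the source may bear on it.

- Compound 1 `COc1cc(OC)cc(N2CCN(C(=O)c3oc(C)nc3-c3ccc(F)cc3)CC2)c1`: 5.6%
- Compound 2 `COc1cc(OC)cc(N2CCN(C(=O)c3oc(C)nc3-c3cccc(F)c3)CC2)c1`: 11.6%

In an ADME assay on microsomes from liver (Mus musculus) for metabolic stability, read by LC-MS, with a stated time of 1 h, tested at 5 uM (a higher number here means that more of the compound is left, a lower number that less of the compound is left), compound 2 stands at 11.6% and compound 1 at 5.6%, so the two lie within the scatter of each other and neither can be ranked above the other. Compound 3 `COc1cc(OC)cc(N2CCN(C(=O)c3oc(C)nc3-c3ccccc3)CC2)c1` follows from compound 2 by one change, (hydrogen in place of fluoro on an aromatic carbon), with hydrogen in place of fluoro on an aromatic carbon. Among the measured compounds shown here, only one measured step bears on it, a number 6 percentage points higher from compound 1 to compound 2 (within the scatter), and that step exchanges 4-fluorophenyl for 3-fluorophenyl. For the measured compounds named here, no measured step takes the fluoro group away, so the data offer no direction, and no step beyond the scatter is expected. The expected step is a number 2.6 percentage points lower from compound 2 to compound 3 (within the scatter). In this assay compound 3 is estimated at 9% with an expected range of 3% to 20%.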

Compound 3, percent of the compound remaining: 0.7%
For compound 3 the middle estimate is 8.3 percentage points above the measured one, and the stated range ends above it.
By their numbers in this assay, from the lowest: compounds 3, 1 and 2 (each within the scatter of the next, the first and the last beyond it).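

In this assay, among the compounds shown here, the fluoro group on the aromatic carbon meta to a large group now proves to matter: going from 3-fluorophenyl to phenyl gives a number 10.9 percentage points lower from compound 2 to compound 3 (beyond the scatter), the first step to pass beyond the scatter, though only a modest one. The same exchange of fluoro for hydrogen, starting from the fluoro group of compound 1 at its other place on the ring, gives a number 4.9 percentage points lower from compound 1 to compound 3 (within the scatter), so among these three compounds the change reads beyond the scatter only when it starts from compound 2. Nothing shown here gives a reason for this difference.

The compounds shown leave open whether a chloro or a methyl group at that same place would match fluoro, or differ from hydrogen at all. They also leave open whether the step would hold with a second fluoro group on the ring or on a changed core.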